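Benzoyl for hydrogen in a leukotriene B4 receptor 1 series

This account rests on a few compounds, and the source may have more. Where it says the series, first, only, none or still open, it means among the compounds named here.

Measured compounds:
compound 1 `CC(=O)c1cc(C=O)c(OCCCCC#N)cc1O` — 3%
compound 2 `C=CCc1ccc(O)cc1OCCCCC#N` — 9%

Of the compounds shown here, two have been measured in an assay on isolated protein for binding affinity to leukotriene B4 receptor 1 (Homo sapiens), tested at 1 uM; on this read-out higher numbers stand for more inhibition at the one concentration tested (going by the name of the read-out) and lower numbers for less inhibition. Compound 1 gives 3%, and compound 2 gives 9%. The two numbers lie within the scatter of each other, so compound 2 does not stand apart from compound 1 on this assay; both are low, and nothing separates them beyond repeat-measurement noise.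

Compound 3 `C=CCc1cc(C(=O)c2ccccc2)c(O)cc1OCCCCC#N` has not yet been measured. It differs from compound 2 in one place: benzoyl in place of hydrogen on an aromatic carbon. Among the compounds with values here, no measured pair shows what this change does in this assay, so there is no step on which to lean; the expectation rests only on the low value of compound 2 and on the fact that a benzoyl group is a sizeable addition to the core of compound 2.

For compound 3 the step of a number 11 percentage points higher from compound 2 to compound 3 (beyond the scatter) is expected to be modest and upward, if anything, with wide uncertainty. Compound 3 is estimated at 20% in this assay, within a range from 0% to 55%.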

Compound 3, a percentage reported as inhibition, at one concentration (the size of the read-out at that concentration, not a potency): 5%
The estimate for compound 3 lay 15 percentage points above the measured number; the measured number falls inside the stated range.
By their numbers in this assay, from the lowest: compounds 1, 3 and 2 (each within the scatter of the next).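

Benzoyl in place of hydrogen on an aromatic carbon, ortho to a hydroxy group, meta to an allyl group and para to a 4-cyanobutoxy group, is the first single-place change that can be read in this assay, and it gives a number 4 percentage points lower from compound 2 to compound 3 (within the scatter). This position therefore carries a benzoyl group, with its six-membered aromatic ring of carbon only, without compound 3 standing apart from compound 2, so this sizeable addition brings no measurable gain at the one concentration tested, and compound 3 remains a low number at 5%. Nothing available explains this outcome.

The compounds shown leave open whether any other group on the same aromatic carbon, such as an amine, a carboxylic acid or a longer chain, would move the number beyond the scatter. They also leave open whether a carboxylic acid in place of the nitrile at the end of the 4-cyanobutoxy group would give a number that stands apart from that of compound 2 in this assay.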